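Working notes: from compound 2 to compound 3

This account rests on a few compounds, and the source may have more. Where it says the series, first, only, none or still open, it means among the compounds named here.

Measured so far in a functional assay on the whole organism with Mus musculus as the target, in the maximal electroshock model; a higher number here means that more compound is needed for the effect, a lower number that less compound is needed:
- compound 1 `CCC1CCSC1=O` gives 232 mg/kg
- compound 2 `CC(C)C1CCSC1=O` gives > 500 mg/kg (a limit)

Compound 2 stands at > 500 mg/kg in this assay, which is a limit of the assay and not a number.

Compound 3 `CC(C)C1(C(C)C)CCSC1=O` changes compound 2 in one place: isopropyl in place of hydrogen on a saturated ring carbon. In short, this is isopropyl in place of hydrogen on a saturated ring carbon.

Within the data shown here, one measured step bears on this change: an at least 2.1-fold higher number from compound 1 to compound 2 (0.33 log units; beyond the scatter). It lies beyond the scatter and came with methyl in place of hydrogen on a saturated chain carbon. That is a different place, and the step has only a lower bound, so it is a weak guide. No clear step from the limit is therefore expected, although a higher number remains possible.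

The expected step is a number no higher from compound 2 to compound 3 (the limit leaves the size open). Compound 3 is estimated at 500 mg/kg, with an expected range of 180 mg/kg to 1200 mg/kg.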

Compound 3, dose for half-maximal effect: > 500 mg/kg
Compound 3 was reported as a limit; the forecaster's own chance of this, stated with the estimate: 55%; the middle value sits exactly at the limit.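

Compound 2 and compound 3 both stand at a limit and not a number in this assay, so no step can be read between them: the limit of > 500 mg/kg in this assay, at which 2 of the 3 values shown sit.

The compounds shown leave open whether isopropyl in place of hydrogen on a saturated ring carbon changes the number at all.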